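The compounds below may be only part of what the source reports. "The series", "measured", "known", "first", "only" and "open" are said of these compounds alone.

Compound 2 `N#CC1=C(N)Oc2c(N)cc3nc4ccccc4nc3c2C12C(=O)N(Cc1cnnn1-c1ccc([N+](=O)[O-])cc1)c1ccccc12` carries a 4-nitrophenyl on an aromatic nitrogen of its five-membered ring. In an ADME assay on HUVEC cells (Homo sapiens) for antiproliferative activity, read by MTT assay, with a stated time of 48 h (a lower number here means a stronger inhibitor, a higher number a weaker inhibitor), compound 2 gives > 50000 nM, which is a limit of the assay and not a number. Its closest measured neighbour is compound 1 `N#CC1=C(N)Oc2c(N)cc3nc4ccccc4nc3c2C12C(=O)N(Cc1cnnn1-c1cccc(C(F)(F)F)c1)c1ccccc12`, in which 3-(trifluoromethyl)phenyl occupies the same position. In this assay compound 1 gives > 50000 nM, again a limit. The step that the two limits leave unreadable from compound 1 to compound 2 is therefore unreadable, because both values sit at the limit of > 50000 nM in this assay, at which 2 of the 2 values shown sit, and nothing separates them.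

Compound 3 `Cc1ccc(-n2nncc2CN2C(=O)C3(C(C#N)=C(N)Oc4c(N)cc5nc6ccccc6nc5c43)c3ccccc32)cc1C` is the next variation on the same nitrogen: 3,4-dimethylphenyl in place of 4-nitrophenyl on an aromatic nitrogen. Going by the values given here, the only measured step bearing on this change is the one from compound 1 to compound 2, and that step gave no readable size, so there is no measured evidence that any aryl group on this nitrogen moves the read-out off the limit. The expectation for compound 3 is accordingly a step that the limit leaves unreadable from compound 2 to compound 3, most likely ending once more at the limit rather than at a number. Compound 3 is estimated at 80000 nM, within 30000 nM to 300000 nM.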

Compound 3, half-maximal inhibitory concentration: > 50000 nM
Compound 3 gave a limit, no number; the forecaster's own chance of this, stated with the estimate: 85%; the middle value does not contradict the limit.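

No new step can be read among compound 1, compound 2 and compound 3, because all three stop at the same value, which is a limit of the assay and not a number: the limit of > 50000 nM in this assay, at which 3 of the 3 values shown sit.

The compounds shown leave open whether any aryl group on this aromatic nitrogen would give a readable number in this assay and how large a step between such groups would be.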